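Aryl ketone series: nitro replaced by methoxy

The source may hold more compounds than are shown below. What is called first, only, known or untested is meant among the compounds shown, and "the series" means these compounds.

Measured so far:
- compound 1, `O=C(CSc1nc2ccccc2[nH]1)c1ccc([N+](=O)[O-])cc1`: "not active" (no number reported)
- compound 2, `O=C(CSc1nc2ccccc2[nH]1)c1ccc(F)cc1`: "not active" (no number reported)
- compound 3, `COc1ccccc1C(=O)CSc1nc2ccccc2[nH]1`: 34.9%

In a functional assay on HT-29 cells (Homo sapiens) for inhibition, read by flow cytometry, tested at 10 uM (a lower number here means less inhibition, a higher number more inhibition at the concentration tested (going by the name of the read-out)), compound 1 gives "not active" (no number reported), reported without a number. Compound 2 gives "not active" (no number reported) in the same way, so no number stands for either. Among the measured compounds shown here, compound 3 gives 34.9%, the only numerical value in the set. Where compound 1 stands is therefore simple: no number, alongside one further entry without a number, while the single numerical value sits with compound 3.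

Compound 4, `COc1ccc(C(=O)CSc2nc3ccccc3[nH]2)cc1`, is not yet measured. It differs from compound 1 as follows: methoxy in place of nitro on an aromatic carbon. For the measured compounds named here, no step between two measured compounds covers this change. The nearest reference is compound 3, which also carries a methoxy group on the ring and gives 34.9%, whereas compound 1 with nitro gives no number. A step upward from compound 1 of modest size is expected, with a real chance that the assay again reports no number. For compound 4 the inhibition is estimated at 20%, within 0% to 45%.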

Compound 4, a percentage reported as inhibition, at one concentration (the size of the read-out at that concentration, not a potency): 52.6%
Beside the measured number, compound 4's estimate is 32.6 percentage points below it; measured number above the stated range.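

No step can be read for compound 4, since compound 1, the compound it differs from in one place, carries no number in this assay. The compounds shown leave open how large the change from nitro to methoxy is on this read-out. No supporting evidence bears on this result.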